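The source may hold more compounds than are shown below. What is called first, only, known or untested is meant among the compounds shown, and "the series" means these compounds.

Notes on the series in a functional assay on A549 cells (Homo sapiens) for inhibition; on this read-out lower numbers stand for stronger inhibition and higher numbers for weaker inhibition. Compound 1 `COc1ccc(/C=C\c2ccc3ccccc3c2)cc1[N+](=O)[O-]` reads > 20000 nM, which is a limit of the assay. Compound 2 `COc1cc(/C=C\c2ccc3ccccc3c2)cc([N+](=O)[O-])c1OC` gives a true number, 590 nM. Compound 3 `COc1c([N+](=O)[O-])cc(/C=C\c2ccc3ccccc3c2)cc1[N+](=O)[O-]` reads > 5000 nM, also a limit, so its standing is known only from one side.

Compound 4 `CN(C)c1c([N+](=O)[O-])cc(/C=C\c2ccc3ccccc3c2)cc1[N+](=O)[O-]` carries one change from it: dimethylamino in place of methoxy on an aromatic carbon. The new group sits ortho to two nitro groups and para to a large group.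

Within the data shown here, no measured step makes this exchange. The nearest evidence is an at least 8.4-fold higher number from compound 2 to compound 3 (0.92 log units; beyond the scatter) and an at least 33-fold lower number from compound 1 to compound 2 (1.53 log units; beyond the scatter), which show that a single exchange on an aromatic carbon can move the number well beyond the scatter. The a step that the two limits leave unreadable from compound 1 to compound 3 cannot be read. Going by these compounds, the direction for compound 4 therefore stays open, and with both nitro groups kept a return towards compound 2 at 590 nM is not expected.

The expected step that the limit leaves unreadable from compound 3 to compound 4 is small and poorly defined. For compound 4 the estimated value in this assay is 8000 nM, with an expected range of 2500 nM to 30000 nM.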

Compound 4, half-maximal inhibitory concentration: > 5000 nM
Compound 4 gave a limit, no number; the forecaster's own chance of this, stated with the estimate: 70%; the middle value lies beyond the limit too.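

In this assay compound 4 gives > 5000 nM as a limit and not a number. Among these compounds, compound 3 also sits at a limit, so no step between compound 3 and compound 4 can be read. Going by these compounds, whether dimethylamino and methoxy differ at all with both nitro groups kept stays open.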